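Swapping the oxan-2-yl group for 2,3-dihydroxypropyl

This account rests on a few compounds, and the source may have more. Where it says the series, first, only, none or still open, it means among the compounds named here.

In a functional assay on A549 cells (Homo sapiens) for cytotoxicity, read by MTT assay, with a stated time of 72 h (a lower number here means a stronger inhibitor, a higher number a weaker inhibitor), compound 1 (`O=C1c2c[n+]([O-])c3ccccc3c2C(=O)c2c1c1ccccc1n2CCCCN1CCCCC1`) gives 150 nM and compound 2 (`O=C1c2c[n+]([O-])c3ccccc3c2C(=O)c2c1c1ccccc1n2Cc1cn([C@@H]2O[C@H](CO)[C@@H](O)[C@H](O)[C@H]2O)nn1`) gives 560 nM as the higher of the two numbers, a gap beyond the scatter. These compounds differ in more than one place, so neither value isolates the next change. Compound 3 (`O=C1c2c[n+]([O-])c3ccccc3c2C(=O)c2c1c1ccccc1n2Cc1cn(C[C@@H](O)CO)nn1`) has 2,3-dihydroxypropyl in place of 3,4,5-trihydroxy-6-(hydroxymethyl)oxan-2-yl on an aromatic nitrogen and is still unmeasured. The expected step (a 1.4-fold lower number from compound 2 to compound 3 (0.15 log units; within the scatter)) is small, toward a lower number, and may not exceed the scatter. For compound 3 the estimated value is 400 nM with an expected range from 150 nM to 1100 nM in this series.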

Compound 3, half-maximal inhibitory concentration: 390 nM
The estimate for compound 3 lay 1.0-fold (0.01 log units) above the measured number; the measured number falls inside the stated range.
By their numbers in this assay, from the lowest: compound 1; then compounds 3 and 2 (each within the scatter of the next).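

In this assay, 2,3-dihydroxypropyl in place of 3,4,5-trihydroxy-6-(hydroxymethyl)oxan-2-yl on the aromatic nitrogen gives a 1.4-fold lower number from compound 2 to compound 3 (0.16 log units; within the scatter), so this position tolerates loss of the six-membered ring without a step beyond the scatter. On the saturated chain carbon bound to an aromatic nitrogen, 1-(2,3-dihydroxypropyl)-1H-1,2,3-triazol-4-yl in place of 3-(piperidin-1-yl)propyl gives a 2.6-fold higher number from compound 1 to compound 3 (0.41 log units; beyond the scatter), a modest step. Nothing measured here accounts for either step. Open, as far as these compounds go, is whether a primary amine or a carboxylic acid on this aromatic nitrogen would shift the number beyond the scatter.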